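The source may hold more compounds than are shown below. What is called first, only, known or untested is meant among the compounds shown, and "the series" means these compounds.

Measured so far in a functional assay on HEK293 cells for positive allosteric modulation of metabotropic glutamate receptor 5 (Rattus norvegicus), read by fluorescence and calcium flux; a lower number here means that less compound is needed, a higher number that more compound is needed for the effect:
Compound 1, `O=C(COCc1ccccc1)N1CCN(c2cccnc2)CC1`: "not active" (no number reported)
Compound 2, `COC(=O)c1ccccc1N1CCN(C(=O)COCc2ccccc2)CC1`: a limit, > 10000 nM

Compound 1 stands without a number of its own in this assay: it is reported only as "not active" (no number reported), with no half-maximal effective concentration attached. Compound 2 gives only > 10000 nM, which is a limit of the assay rather than a measured number. The only quantitative mark among the values shown is therefore (the limit of > 10000 nM in this assay, at which 1 of the 2 values shown sits), so neither compound offers a firm foothold.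

Compound 3, `O=C(COCc1ccccc1)N1CCN(c2ncccn2)CC1`, is not yet measured. It differs from compound 1 in one place: pyrimidin-2-yl in place of pyridin-3-yl on an amine nitrogen in a ring. For the measured compounds named here, no step between measured compounds can be drawn on here, so the size of the step from compound 1 to compound 3 in this assay cannot be anchored; the expectation is no step beyond the usual scatter, in either direction, with a limit again the most likely outcome.

Compound 3 is estimated at 15000 nM, within a range from 5000 nM to 50000 nM, and most probably the assay will again report only a limit.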

Compound 3, half-maximal effective concentration: "not active" (no number reported)
For compound 3 the study gives words and no number, and the estimate cannot be compared.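

For the compounds shown here, compound 1 and compound 3 are both reported in words alone in this assay, with no number, so no step between them can be read. The compounds shown leave open whether pyrimidin-2-yl in place of pyridin-3-yl alters the result at all, and what would give a measured value; the only quantitative mark remains a limit: the limit of > 10000 nM in this assay, at which 1 of the 3 values shown sits.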